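The source may hold more compounds than are shown below. What is called first, only, known or untested is meant among the compounds shown, and "the series" means these compounds.

In a physicochemical assay for lipophilicity, using the shake flask method (on this read-out lower numbers stand for lower lipophilicity and higher numbers for higher lipophilicity), compound 1 `Nc1ncnc(Oc2ccc(NC(=O)C3(C(=O)Nc4ccc(F)cc4)CC3)cc2F)c1/C=N/OCCCO` gives 2.67 and compound 2 `Nc1ncnc(Oc2ccc(NC(=O)C3(C(=O)Nc4ccc(F)cc4)CC3)cc2F)c1/C=N/OCc1ccccc1` gives 4.45, the higher of the two numbers; the step of a number 1.78 log units higher from compound 1 to compound 2 (beyond the scatter) separates them. Compound 3 `Nc1ncnc(Oc2ccc(NC(=O)C3(C(=O)Nc4ccc(F)cc4)CC3)cc2F)c1/C=N/OCCCN1CCCC1` differs from compound 2 by 2-(pyrrolidin-1-yl)ethyl in place of phenyl on a saturated chain carbon bound to an oxygen. For the measured compounds named here, only the step from compound 1 to compound 2 bears on this change, because it also swapped the phenyl at this carbon and moved a number 1.78 log units higher from compound 1 to compound 2 (beyond the scatter); a large step downward in this assay is therefore expected, of roughly the size seen there, namely a number 1.85 log units lower from compound 2 to compound 3 (beyond the scatter). For compound 3 the estimate is 2.6, with a range from 1.8 to 3.4.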

Compound 3, partition coefficient: 3.82
For compound 3 the middle estimate is 1.22 log units below the measured one; the measured number lies above the stated range.
By their numbers in this assay, from the lowest: compound 1; then compound 3; then compound 2.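

In this assay, 2-(pyrrolidin-1-yl)ethyl in place of phenyl on a saturated chain carbon bound to an oxygen gives only a modest step, a number 0.63 log units lower from compound 2 to compound 3 (beyond the scatter), so the two groups lie closer together than phenyl and 2-hydroxyethyl do. Pyrrolidin-1-yl in place of hydroxy on the same chain gives a large step, a number 1.15 log units higher from compound 1 to compound 3 (beyond the scatter), which places this end group well clear of the hydroxy group. Nothing available explains either step. From the compounds shown here alone, whether a morpholine, a dimethylamine or a longer chain would follow compound 3 remains open.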